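Cyclopentylsulfanyl for pyrrolidin-1-yl: expected cytotoxicity of compound 4

The compounds below may be only part of what the source reports. "The series", "measured", "known", "first", "only" and "open" are said of these compounds alone.

Four compounds share one core and differ only in the group carried on it. Compound 1 `CN(C)c1nc(N)nc2c1ncn2/C=C1/CC1(CO)CO` carries a dimethylamino group, compound 2 `Nc1nc(OCc2ccccc2)c2ncn(/C=C3/CC3(CO)CO)c2n1` a benzyloxy group, compound 3 `Nc1nc(N2CCCC2)c2ncn(/C=C3/CC3(CO)CO)c2n1` a pyrrolidin-1-yl group, and compound 4 `Nc1nc(SC2CCCC2)c2ncn(/C=C3/CC3(CO)CO)c2n1` a cyclopentylsulfanyl group.

The read-out is an ADME assay on MOLT-3 cells (Homo sapiens) for cytotoxicity, with a stated time of 7 days; on this read-out lower numbers stand for higher toxicity in this test and higher numbers for lower toxicity in this test. For compound 3 there is no number in this assay; its entry reads "not determined" (no result reported). Compound 1 likewise gives "not determined" (no result reported). The only measured entry is a limit: compound 2 reaches > 20000 nM, which is the limit of this assay rather than a number. That is summed up by the limit of > 20000 nM in this assay, at which 1 of the 3 values shown sits.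

The step from compound 3 to compound 4 is cyclopentylsulfanyl in place of pyrrolidin-1-yl on an aromatic carbon. Among the compounds with values here, since no step between measured compounds exists here, no size can be taken from the data; the one result available is a limit, so compound 4 is expected to sit in the same region, with no difference beyond the usual scatter of this assay.

Compound 4 is therefore estimated at about 30000 nM, within a range from 8000 nM to 100000 nM, most likely reported again only as a limit.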

Compound 4, half-maximal cytotoxic concentration: > 20000 nM
Compound 4 was reported as a limit; the forecaster's own chance of this, stated with the estimate: 70%; the middle value is on the limit's open side.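

The step from compound 2 to compound 4 cannot be read, because each of the two results is a limit of the assay and not a number: the limit of > 20000 nM in this assay, at which 2 of the 4 values shown sit.

The compounds shown leave open whether changing the group on the shared core alters the result in this assay at all, and by how much.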